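From compound 3 to compound 4: propyl for cyclopropyl

The source may hold more compounds than are shown below. What is called first, only, known or untested is meant among the compounds shown, and "the series" means these compounds.

Among the measured compounds shown here, in an ADME assay on BCBL1 cells (Homo sapiens) for cytotoxicity, with a stated time of 7 days (on this read-out lower numbers stand for higher toxicity in this test and higher numbers for lower toxicity in this test), compound 3 (`Nc1nc(NC2CC2)c2ncn(/C=C3/CC3(CO)CO)c2n1`) gives 71500 nM as the only actual number. Compound 1 (`CCOc1nc(N)nc2c1ncn2/C=C1/CC1(CO)CO`) reads > 20000 nM as a limit of the assay. Compound 2 (`CCCCCCCCOc1nc(N)nc2c1ncn2/C=C1/CC1(CO)CO`) reads > 20000 nM as a limit too. Compound 4 (`CCCNc1nc(N)nc2c1ncn2/C=C1/CC1(CO)CO`) has propyl in place of cyclopropyl on a nitrogen on an aromatic ring is the whole difference. For the measured compounds named here, two measured steps bear on it: a step that the limit leaves unreadable from compound 1 to compound 3 and a step that the limit leaves unreadable from compound 2 to compound 3 give no size to scale from. In this assay the expected outcome is a 1.2-fold lower number from compound 3 to compound 4 (0.08 log units; within the scatter) and nothing beyond the scatter, in neither direction. For compound 4 the estimated value is 60000 nM with 25000 nM to 120000 nM as the expected range.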

Compound 4, half-maximal cytotoxic concentration: > 20000 nM
Compound 4: a limit, no number; the forecaster's own chance of this, stated with the estimate: 45%; the middle value is on the limit's open side.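

In this assay, among the compounds shown here, no step from compound 1, compound 2 or compound 3 to compound 4 can be read: the limit of > 20000 nM in this assay, at which 3 of the 4 values shown sit. The compounds shown leave open whether propyl and cyclopropyl on a nitrogen on an aromatic ring differ at all in this read-out.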